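The compounds below may be only part of what the source reports. "The series", "measured", "known", "first", "only" and "open" are said of these compounds alone.

Measured so far in an ADME assay on Vero cells (Chlorocebus sabaeus) for cytotoxicity, read by MTT assay, with a stated time of 72 h (a lower number here means that less compound is tolerated, a higher number that more compound is tolerated), where each value is a limit and not a number:
- Compound 1 `O=C(CC1CCCCC1)N1CCN(c2nc(=O)c3cc(C(F)(F)F)cc([N+](=O)[O-])c3s2)CC1`: > 125000 nM
- Compound 2 `O=c1nc(N2CCN(CC3CCCCC3)CC2)sc2c([N+](=O)[O-])cc(C(F)(F)F)cc12`: > 125000 nM
- Compound 3 `CC1COC2(CCN(c3nc(=O)c4cc(C(F)(F)F)cc([N+](=O)[O-])c4s3)CC2)O1`: > 125000 nM

Compound 2 has only a limit and shares it with the other two compounds: the limit of > 125000 nM in this assay, at which 3 of the 3 values shown sit. Compound 4 `CCC(C)C(=O)N1CCN(c2nc(=O)c3cc(C(F)(F)F)cc([N+](=O)[O-])c3s2)CC1` differs from it as follows: (sec-butyl)carbonyl in place of cyclohexylmethyl on an amine nitrogen in a ring. In words, (sec-butyl)carbonyl stands in place of cyclohexylmethyl on an amine nitrogen in a ring.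

Within the data shown here, the one measured step at that place is a step that the two limits leave unreadable from compound 1 to compound 2. Compound 1 also carries a carbonyl group on that nitrogen, and its value is the limit > 125000 nM. Compound 4 is therefore expected to stay near that limit, with no change beyond the scatter. The expected step is a number no higher from compound 2 to compound 4 (the limit leaves the size open). In this assay, the estimate for compound 4 is 125000 nM, with an expected range from 70000 nM to 200000 nM.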

Compound 4, half-maximal cytotoxic concentration: > 125000 nM
Compound 4 was reported as a limit; the forecaster's own chance of this, stated with the estimate: 85%; the middle value sits exactly at the limit.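

Compound 1, compound 2 and compound 4 each give a limit and not a number, so no step among them can be read: the limit of > 125000 nM in this assay, at which 4 of the 4 values shown sit.

The compounds shown leave open what actual number any of them would give in this assay, and whether the group on the ring nitrogen changes it.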